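The source may report more compounds than this note shows. Statements on the series, on what has been measured and on what is new or still open speak of the compounds shown alone.

Working notes on the series, read in an ADME assay on J774 cells (Mus musculus) for cytotoxicity (on this read-out higher numbers stand for an effect only at larger amounts of compound and lower numbers for an effect already at smaller amounts), throughout. Compound 3 (`CCCCCc1cc2c(=O)c(C(=O)OC)c[nH]c2cc1OCCOc1ccccc1`) carries the pentyl group, and in this assay compound 3 gives > 20000 nM as a limit of the assay, not a number. Compound 1 (`CCCCc1cc2c(=O)c(C(=O)OC)c[nH]c2cc1OCCOc1ccccc1`) gives > 20000 nM as a limit too. Compound 2 (`CCCc1cc2c(=O)c(C(=O)OC)c[nH]c2cc1OCCOc1ccccc1`) likewise gives > 20000 nM as a limit. The position of the series is therefore the limit of > 20000 nM in this assay, at which 3 of the 3 values shown sit, and nothing finer.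

Compound 4 (`COC(=O)c1c[nH]c2cc(OCCOc3ccccc3)c(Br)cc2c1=O`) is not yet measured. Its difference from compound 3 is bromo in place of pentyl on an aromatic carbon and amounts to bromo in place of pentyl on an aromatic carbon. The measured steps that bear on it are chain steps only: a step that the two limits leave unreadable from compound 1 to compound 2 and a step that the two limits leave unreadable from compound 1 to compound 3 and a step that the two limits leave unreadable from compound 2 to compound 3 all lack a readable size. None of them exchanges a chain for bromo, so the support is indirect.

No change beyond the scatter is expected, and no direction is favoured: the expected move is a number no higher from compound 3 to compound 4 (the limit leaves the size open) in this assay. For compound 4 the estimate is 20000 nM with an expected range from 10000 nM to 40000 nM in this reading, most likely reported as a limit again.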

Compound 4, half-maximal effective concentration: > 20000 nM
Compound 4: only a limit was reported (the forecaster's own chance of this, stated with the estimate: 80%); the middle value lies on the limit itself.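

No step to compound 4 from compound 1, compound 2 or compound 3 can be read in this assay, and all four compounds stand at the same limit of the assay: the limit of > 20000 nM in this assay, at which 4 of the 4 values shown sit.

The compounds shown leave open at what concentration any of them acts, and whether bromo and the chains differ at all.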